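Extending the alkylamino chain: compound 3 to compound 4

This account rests on a few compounds, and the source may have more. Where it says the series, first, only, none or still open, it means among the compounds named here.

Measured in an in vitro assay on HEK-tsA201 cells for antagonist activity at Neuronal acetylcholine receptor; alpha4/beta2 (Homo sapiens), read by fluorescence and calcium flux; on this read-out lower numbers stand for stronger inhibition and higher numbers for weaker inhibition:
compound 1 `CCCOc1ccc(C(=O)Nc2cccc(Br)n2)cc1`, 80700 nM
compound 2 `CCCOc1ccc(C(=O)Nc2cccc(CC)n2)cc1`, 37600 nM
compound 3 `CCCNc1cccc(NC(=O)c2ccc(OCCC)cc2)n1`, 15400 nM

Compound 3 carries the lowest number of the three. Going to it from compound 1 reads a 5.2-fold lower number from compound 1 to compound 3 (0.72 log units; beyond the scatter) and from compound 2 reads a 2.4-fold lower number from compound 2 to compound 3 (0.39 log units; beyond the scatter); between the other two, a 2.1-fold lower number from compound 1 to compound 2 (0.33 log units; beyond the scatter). Compound 4 `CCCCNc1cccc(NC(=O)c2ccc(OCCC)cc2)n1` differs from compound 3 by methyl in place of hydrogen on a saturated chain carbon, three bonds along the chain from a nitrogen on an aromatic ring. Going by the values given here, none of the measured steps lengthens a chain; each exchanges the whole group on the ring carbon, and all were modest. Only a small step is therefore expected, close to the scatter. In this assay compound 4 is estimated at 11000 nM, with a range of 5000 nM to 25000 nM. The expected step is a 1.4-fold lower number from compound 3 to compound 4 (0.15 log units; within the scatter).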

Compound 4, half-maximal inhibitory concentration: 54100 nM
Estimate against measurement, compound 4: 4.9-fold (0.69 log units) below; the measured number lies above the stated range.
By their numbers in this assay, from the lowest: compound 3; then compounds 2, 4 and 1 (each within the scatter of the next, the first and the last beyond it).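

Lengthening propylamino to butylamino is not a neutral change at this place: in this assay, the added methyl, three bonds along the chain from a nitrogen on an aromatic ring, gives a 3.5-fold higher number from compound 3 to compound 4 (0.55 log units; beyond the scatter). The advantage of propylamino over the other groups is not kept by butylamino, with ethyl to butylamino reading a 1.4-fold higher number from compound 2 to compound 4 (0.16 log units; within the scatter) and bromo to butylamino reading a 1.5-fold lower number from compound 1 to compound 4 (0.17 log units; within the scatter).

Open, going by these compounds, is how ethylamino, pentylamino or a branched amine such as isopropylamino would read on the same ring carbon. No evidence at hand accounts for the effect of this added methyl.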